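The compounds below may be only part of what the source reports. "The series", "measured", "known", "first", "only" and "open" are said of these compounds alone.

Measured so far:
compound 1 `CN(Cc1cccc(Cl)c1)C(=O)c1cc2c(Cc3ccccc3)n[nH]c2cc1O` — 5300 nM
compound 2 `Cc1ccccc1Cc1n[nH]c2cc(O)c(C(=O)N(C)Cc3ccccc3)cc12` — "not determined" (no result reported)

In a functional assay on A2780 cells (Homo sapiens) for antiproliferative activity, read by resazurin assay, with a stated time of 72 h (a lower number here means a stronger inhibitor, a higher number a weaker inhibitor), compound 1 gives 5300 nM. For compound 2 the entry in this assay reads "not determined" (no result reported), so compound 2 stands without a value of its own; the only anchor for the series is compound 1. Compound 3 `CCc1ccc(Cc2n[nH]c3cc(O)c(C(=O)N(C)Cc4ccccc4)cc23)cc1` differs from compound 2 by one change: 4-ethylphenyl in place of 2-methylphenyl on a saturated chain carbon bound to an aromatic carbon. Going by the values given here, no step between measured compounds is available to size this change, so the expectation is that it moves this assay by no more than the usual scatter, in no fixed direction. Compound 3 is therefore expected to give about 5000 nM in this assay, between 1500 nM and 20000 nM.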

Compound 3, half-maximal inhibitory concentration: > 10000 nM
Compound 3: no number, only a limit; the forecaster's own chance of this, stated with the estimate: 25%; middle value at least 2.0-fold (0.30 log units) from the limit.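

No step can be read between compound 2, which stands without a number, and compound 3. Compound 3 gives > 10000 nM, which is a limit. Still open, on these data alone, is how far 4-ethylphenyl in place of 2-methylphenyl shifts activity, if at all.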